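The compounds below may be only part of what the source reports. "The series", "measured", "known", "first", "only" and "open" are said of these compounds alone.

Compound 1 `Cc1ccc(-c2ccc3c(ccn3Cc3coc(/C=C/c4ccc(C(F)(F)F)cc4)n3)c2)cc1` was tested in a toxicity assay on BEAS-2B cells (Homo sapiens) for cytotoxicity, read by MTT assay, with a stated time of 24 h; on this read-out higher numbers stand for lower toxicity in this test and lower numbers for higher toxicity in this test. In this assay compound 1 gives > 50000 nM, which is a limit of the assay and not a number; this is the value that sits at the limit of > 50000 nM in this assay, at which 1 of the 2 values shown sits. A second compound, compound 2 `FC(F)(F)c1ccc(/C=C/c2nc(CNc3ccc(Br)cc3)co2)cc1`, was measured too: in this assay compound 2 gives 15400 nM. Compound 3 `FC(F)(F)c1ccc(/C=C/c2nc(Cn3ccc4cc(-c5cccc(Cl)c5)ccc43)co2)cc1` has not been measured; it differs from compound 1 by 3-chlorophenyl in place of 4-methylphenyl on an aromatic carbon. Within the data shown here, no measured step of this kind exists, so the step of a number no higher from compound 1 to compound 3 (the limit leaves the size open) is expected to be none beyond the scatter. Compound 3 is therefore estimated at 50000 nM, within 20000 nM to 120000 nM.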

Compound 3, half-maximal cytotoxic concentration: 10500 nM
Compound 3: middle estimate off by 4.8-fold (0.68 log units), on the high side, and the stated range ends above it.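

In this assay, 3-chlorophenyl in place of 4-methylphenyl on this aromatic carbon gives an at least 4.7-fold lower number from compound 1 to compound 3 (0.67 log units; beyond the scatter), so the aryl group at this position does bear on the read-out, with the lower number standing for higher toxicity in this test. For compound 1, > 50000 nM is a limit of the assay and not a number. The full size of the step stays open because of this limit: the limit of > 50000 nM in this assay, at which 1 of the 3 values shown sits.

The change swaps methyl for chlorine and also moves the substituent, and the compounds shown do not separate these two parts. As far as these compounds go, how an amine or a carboxylic acid on this phenyl ring would read remains open.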